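This account rests on a few compounds, and the source may have more. Where it says the series, first, only, none or still open, it means among the compounds named here.

The shared core of compound 1 `COC(=O)c1ccc(-c2cccc(NC(=O)C(Cl)Cl)c2)cc1` carries a methoxycarbonyl group and in a functional assay on A549 cells (Homo sapiens) for cytotoxicity, read by MTT assay, with a stated time of 68 h (on this read-out lower numbers stand for stronger inhibition and higher numbers for weaker inhibition), compound 1 gives > 50000 nM, which is a limit of the assay and not a number. Compound 2 `O=C(Nc1cccc(-c2ccc(-c3ccccc3)cc2)c1)C(Cl)Cl` bears a phenyl group instead, and in this assay compound 2 likewise gives > 50000 nM, again a limit. For the measured compounds named here, compound 3 `COc1ccc(-c2cccc(NC(=O)C(Cl)Cl)c2)cc1` carries a methoxy group, and in this assay compound 3 gives 8530 nM, the only number among the three values, since (the limit of > 50000 nM in this assay, at which 2 of the 3 values shown sit). The steps into compound 3 are readable at least in part: an at least 5.8-fold lower number from compound 1 to compound 3 (0.76 log units; beyond the scatter) and an at least 5.8-fold lower number from compound 2 to compound 3 (0.76 log units; beyond the scatter), whereas a step that the two limits leave unreadable from compound 1 to compound 2. Compound 4 `O=C(Nc1cccc(-c2ccc(C(F)(F)F)cc2)c1)C(Cl)Cl` differs from compound 3 by trifluoromethyl in place of methoxy on an aromatic carbon. Going by the values given here, no measured step replaces methoxy with trifluoromethyl, but both steps that exchange methoxy for another group move the number beyond the limit. Given an at least 5.8-fold lower number from compound 1 to compound 3 (0.76 log units; beyond the scatter) and an at least 5.8-fold lower number from compound 2 to compound 3 (0.76 log units; beyond the scatter), compound 4 is therefore expected to give a higher number, a 3.5-fold higher number from compound 3 to compound 4 (0.55 log units; beyond the scatter), with a fair chance that only a limit is reported. Compound 4 is estimated at 30000 nM, within 8000 nM to 100000 nM.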

Compound 4, half-maximal inhibitory concentration: 23500 nM
Compound 4: middle estimate off by 1.3-fold (0.11 log units), on the high side, within the range that was stated.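

Unlike methoxycarbonyl and phenyl, trifluoromethyl at this position, para to a large group, gives a number and not a limit, so in this assay an exchange with methoxy can be sized: there is a 2.8-fold higher number from compound 3 to compound 4 (0.44 log units; beyond the scatter). Trifluoromethyl also improves on the two groups held at the limit, with an at least 2.1-fold lower number from compound 2 to compound 4 (0.32 log units; beyond the scatter) and an at least 2.1-fold lower number from compound 1 to compound 4 (0.32 log units; beyond the scatter). Among the groups shown, methoxy thus gives the lowest number and trifluoromethyl the next lowest, while the last two steps are bounds only and the order of methoxycarbonyl and phenyl stays unresolved: the limit of > 50000 nM in this assay, at which 2 of the 4 values shown sit.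

What the compounds shown leave open is why methoxy gives a lower number than trifluoromethyl. They also leave open how an amine, a hydroxyl group or a carboxylic acid at this position would compare, and whether a longer chain such as ethoxy would keep or lower the number of compound 3.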